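The compounds below may be only part of what the source reports. "The series", "measured", "known", "first", "only" and "open" are said of these compounds alone.

In a functional assay on MCF7 cells (Homo sapiens) for antiproliferative activity (on this read-out higher numbers stand for weaker inhibition and lower numbers for stronger inhibition), compound 1 (`CCCCOc1ccc(C(=O)Nc2cc3ccc(OC4CCN(C)CC4)c(C)c3oc2=O)cc1CC=C(C)C`) gives 1440 nM and compound 2 (`Cc1c(OC2CCN(C)CC2)ccc2cc(NC(=O)c3ccc(O)c(CCC(C)C)c3)c(=O)oc12`) gives 1250 nM while compound 3 (`C=CCc1cc(C(=O)Nc2cc3ccc(OC4CCN(C)CC4)c(C)c3oc2=O)ccc1OC(C)=O`) gives 2000 nM on the same read-out. The value of compound 3 lies within the scatter of both others, so the three cannot be told apart. Compound 4 (`CC(=O)Oc1ccc(C(=O)Nc2cc3ccc(OC4CCN(C)CC4)c(C)c3oc2=O)cc1Cl`) differs from compound 3 in one place: chloro in place of allyl on an aromatic carbon ortho to an acetoxy group. Among the compounds with values here, no step between measured compounds covers this change, so the expectation rests on compound 3 at 2000 nM alone, and no step beyond the scatter is expected in this assay in either direction. The estimated 1.1-fold lower number from compound 3 to compound 4 (0.05 log units; within the scatter) stays within the scatter. For compound 4 the expected value is 1800 nM with an estimated range from 700 nM to 4500 nM around it.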

Compound 4, half-maximal inhibitory concentration: 1610 nM
The estimate for compound 4 lay 1.1-fold (0.05 log units) above the measured number; low and high end bracket the measured number.
By their numbers in this assay, from the lowest: compounds 2, 1, 4 and 3 (each within the scatter of the next).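

In this assay, chloro in place of allyl, ortho to an acetoxy group, gives a 1.2-fold lower number from compound 3 to compound 4 (0.09 log units; within the scatter). Within the data shown here, this is the first comparison that differs in one place, and it shows that this position tolerates the exchange of allyl for chloro with no step that can be told from the scatter. Nothing available offers a reason for this result. As far as these compounds go, whether an amine, a carboxylic acid or a longer chain at this position would also stay within the scatter remains open. So does whether chloro would read the same with a hydroxy group in place of the acetoxy group.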